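The compounds below may be only part of what the source reports. "The series", "measured", "known", "first", "only" and "open" are said of these compounds alone.

In a functional assay on HT-29 cells (Homo sapiens) for antiproliferative activity, read by MTT assay, with a stated time of 24 h (on this read-out lower numbers stand for stronger inhibition and higher numbers for weaker inhibition), three compounds built on one shared core have been measured. Compound 1 (`COc1ccc(C(=O)/C=C/c2ccc([N+](=O)[O-])cc2)c2c1C=CC(C)(C)O2`) gives 3730 nM, compound 2 (`COc1ccc(C(=O)/C=C/c2cccc([N+](=O)[O-])c2)c2c1C=CC(C)(C)O2`) gives 4260 nM, and compound 3 (`COc1ccc(C(=O)/C=C/c2ccccn2)c2c1C=CC(C)(C)O2`) gives 2120 nM. Compound 3 does not stand apart from the other two, as the steps that reach it are a 1.8-fold lower number from compound 1 to compound 3 (0.25 log units; within the scatter) and a 2.0-fold lower number from compound 2 to compound 3 (0.30 log units; within the scatter). The remaining pair shows the same picture, with a 1.1-fold higher number from compound 1 to compound 2 (0.06 log units; within the scatter).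

Compound 4 (`COc1ccc(C(=O)/C=C/c2cccc(O)c2)c2c1C=CC(C)(C)O2`) differs from compound 3 in one place: 3-hydroxyphenyl in place of pyridin-2-yl on a double-bonded chain carbon bound to a double-bonded chain carbon. All three measured steps are exchanges at this same place, on a double-bonded chain carbon bound to a double-bonded chain carbon, so they bear directly on the new change. None of them goes beyond the scatter. Going by the values given here, still, no measured compound carries 3-hydroxyphenyl, so these steps offer only indirect guidance, and the expected range is kept wide.

On this evidence, no step beyond the scatter is expected in this assay. The estimated step is a 1.4-fold higher number from compound 3 to compound 4 (0.15 log units; within the scatter). For compound 4 the expected value is 3000 nM. The estimated range for compound 4 runs from 1200 nM to 7500 nM.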

Compound 4, half-maximal inhibitory concentration: > 10000 nM
Compound 4 was reported as a limit (the forecaster's own chance of this, stated with the estimate: 5%); middle value at least 3.3-fold (0.52 log units) away from the limit.
By their numbers in this assay, from the lowest: compounds 3, 1 and 2 (each within the scatter of the next). At a limit, above all of these: compound 4.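

Compound 4 is reported only as a limit: the limit of > 10000 nM in this assay, at which 1 of the 4 values shown sits.

Every earlier exchange at this place, on a double-bonded chain carbon bound to a double-bonded chain carbon, stayed within the scatter, so pyridin-2-yl, 3-nitrophenyl and 4-nitrophenyl could not be told apart in this assay. Going by these compounds alone, the 3-hydroxyphenyl group is the first to separate itself, with an at least 4.7-fold higher number from compound 3 to compound 4 (0.67 log units; beyond the scatter), an at least 2.6-fold higher number from compound 1 to compound 4 (0.42 log units; beyond the scatter) and an at least 2.3-fold higher number from compound 2 to compound 4 (0.37 log units; beyond the scatter), and each of these steps is a lower bound. The position is therefore not indifferent to the group it carries, and even the exchange of hydroxy for nitro on an aromatic carbon alone is enough to move the number beyond the scatter.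

From the compounds shown here alone, how far compound 4 lies past its limit remains unknown, and so does the true size of all three steps. Going by these compounds, it also remains open whether the change follows the hydroxy group itself or its place on the ring, which a 4-hydroxyphenyl, 3-methoxyphenyl or 3-aminophenyl group at this position could help to separate.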